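A few compounds are considered here, and "the series" means these few. Any claim that something is new, unique, unknown or untested is made for them only; others in the source may bear on it.

Measured in an ADME assay on microsomes from liver (Homo sapiens) for metabolic stability, read by LC-MS, with NADPH named in the record, with a stated time of 60 min, tested at 1 uM, in the absence of a further agent; a higher number here means that more of the compound is left, a lower number that less of the compound is left:
Compound 1 `COc1ccc(-c2c(C)nc3c(N4CC[C@@H](NC(=O)Nc5ccccc5)C4)cc(C)nn23)cc1OC` gives > 95%
Compound 2 `COc1ccc(-c2c(C)nc3c(N4CC[C@@H](NC(=O)Oc5cccc(C)c5)C4)cc(C)nn23)cc1OC` gives > 95%
Compound 3 `COc1ccc(-c2c(C)nc3c(N4CC[C@@H](NS(=O)(=O)c5cccs5)C4)cc(C)nn23)cc1OC` gives > 95%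

Compound 3 stands at > 95%, which is a limit and not a number. It shares that position with the other two compounds, as the record shows: the limit of > 95% in this assay, at which 3 of the 3 values shown sit. Compound 4 `COc1ccc(-c2c(C)nc3c(N4CC[C@@H](NS(=O)(=O)c5ccc(C#N)cc5)C4)cc(C)nn23)cc1OC` keeps the shared core and the sulfonamide nitrogen, and carries 4-cyanophenyl in place of thiophen-2-yl on a sulfonyl sulfur.

Among the compounds with values here, three measured steps bear on this change, and none of them has a readable size. They are a step that the two limits leave unreadable from compound 1 to compound 3, a step that the two limits leave unreadable from compound 2 to compound 3 and a step that the two limits leave unreadable from compound 1 to compound 2. None of them exchanges one aromatic group on the sulfonyl sulfur for another, so they offer only indirect guidance. All the same, the three different groups on the amine nitrogen give no sign of a drop in the percent remaining. No step beyond the usual scatter is therefore expected in this assay, although the missing sizes leave room for a drop. The estimated step is a number at least 2 percentage points lower from compound 3 to compound 4 (that floor lies within the scatter). For compound 4 the estimated value is 93%. The expected range for compound 4 runs from 80% to 100%.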

Compound 4, percent of the compound remaining: > 95%
Compound 4: a limit, no number; the forecaster's own chance of this, stated with the estimate: 55%; middle value at least 2 percentage points away from the limit.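

In this assay compound 4 gives > 95% and that is a limit, not a number. Its steps from compound 1, compound 2 and compound 3 therefore cannot be read. The compounds shown leave open how far the percent of compound remaining differs among these groups on the amine nitrogen, and whether any of them lowers it.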